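Thiocarbamoyl on the ring nitrogen: a pyrazoline pair

The source may hold more compounds than are shown below. What is called first, only, known or untested is meant among the compounds shown, and "the series" means these compounds.

Compound 1 `CNC(=O)c1cc(Oc2ccc(C3=NNC(c4ccc(F)cc4)C3)cc2)ccn1`: 6770 nM
Compound 2 `CNC(=O)c1cc(Oc2ccc(C3CC(c4ccc([N+](=O)[O-])cc4)=NN3)cc2)ccn1`: "not determined" (no result reported)
Compound 3 `CNC(=O)c1cc(Oc2ccc(C3=NN(C(N)=S)C(c4ccc(F)cc4)C3)cc2)ccn1`: > 50000 nM

In a functional assay on PC-3 cells (Homo sapiens) for cytotoxicity, read by MTT assay, with a stated time of 72 h (a higher number here means a weaker inhibitor, a lower number a stronger inhibitor), compound 1 gives 6770 nM. For compound 3 the value of > 50000 nM is a limit of this assay, not a number. The step of an at least 7.3-fold higher number from compound 1 to compound 3 (0.86 log units; beyond the scatter) is the change (a group of 3 heavy atoms (1 carbon, 1 nitrogen, 1 sulfur; no ring) in place of a hydrogen atom, on an amine nitrogen in a ring). For compound 2 no result is reported in this assay. The difference between the core of compound 1 and the core of compound 2 is not broken down here.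

Compound 4 `CNC(=O)c1cc(Oc2ccc(C3CC(c4ccc([N+](=O)[O-])cc4)=NN3C(N)=S)cc2)ccn1`, not yet measured, differs from compound 2 by a group of 3 heavy atoms (1 carbon, 1 nitrogen, 1 sulfur; no ring) in place of a hydrogen atom, on an amine nitrogen in a ring. It is the same kind of change as that from compound 1 to compound 3, but the place is not the same: in compound 4 the new group sits next to the ring atom that bears a large group and two ring bonds from the ring atom that bears a 4-nitrophenyl group, whereas in compound 3 it sits next to the ring atom that bears a 4-fluorophenyl group. Because an at least 7.3-fold higher number from compound 1 to compound 3 (0.86 log units; beyond the scatter) reached the limit (the limit of > 50000 nM in this assay, at which 1 of the 3 values shown sits), a weak result is expected here too; compound 2 itself gives no number to anchor it. For compound 4 in this assay the estimated value is 60000 nM, expected between 15000 nM and 250000 nM.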

Compound 4, half-maximal inhibitory concentration: > 50000 nM
Compound 4: a limit, no number; the forecaster's own chance of this, stated with the estimate: 70%; the middle value does not contradict the limit.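

In this assay compound 4 gives > 50000 nM, a limit and not a number. Within the data shown here, with no result reported for compound 2, no step from compound 2 to compound 4 can be read. The result joins another at the same limit: the limit of > 50000 nM in this assay, at which 2 of the 4 values shown sit. The compounds shown leave open what the added thiocarbamoyl group does on the core of compound 2.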